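This account rests on a few compounds, and the source may have more. Where it says the series, first, only, none or still open, it means among the compounds named here.

Measured compounds:
Compound 1, `O=C(CCc1cccc2c1B(O)OC2)Nc1ccccc1`, gives 350 nM in a functional assay on HCT-116 cells (Homo sapiens) for antiproliferative activity, read by MTT assay, with a stated time of 72 h; a higher number here means a weaker inhibitor, a lower number a stronger inhibitor.
Compound 2, `O=C(CCc1cccc2c1B(O)OC2)Nc1nccs1`, reaches only the limit of > 100000 nM in this assay, which is a limit of the assay and not a number.

Within the data shown here, compound 1 is the only compound here with a true number; the one other value shown is a limit. Among the measured compounds shown here, the single measured step, an at least 280-fold higher number from compound 1 to compound 2 (2.45 log units; beyond the scatter), swaps the whole ring on the amide nitrogen for a different one and so does not match the change to compound 3, `O=C(CCc1cccc2c1B(O)OC2)Nc1cccc(-c2cccc(F)c2)c1`, where (3-fluorophenyl in place of hydrogen on an aromatic carbon). That change keeps the phenyl ring and adds a 3-fluorophenyl meta to a large group. For the measured compounds named here, no measured step bears on it, so the expectation rests on compound 1 alone, with no clear direction and no step beyond the scatter expected. The estimated step is a 1.1-fold higher number from compound 1 to compound 3 (0.06 log units; within the scatter). Compound 3 is expected near 400 nM, between 100 nM and 2000 nM.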

Compound 3, half-maximal inhibitory concentration: 460 nM
Compound 3: middle estimate off by 1.2-fold (0.06 log units), on the low side; measured number inside the range.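

Adding a 3-fluorophenyl on an aromatic carbon of the phenyl ring of compound 1 gives a 1.3-fold higher number from compound 1 to compound 3 (0.12 log units; within the scatter), so this assay does not separate the two compounds. Among these compounds, until now, the only change with a readable step had replaced the whole phenyl ring; this one keeps that ring and shows that this position can carry a second aromatic ring with no change beyond the scatter. Nothing shown here explains why the added ring leaves the number within the scatter.

The compounds shown leave open whether a plain phenyl, without the fluorine, would behave the same way at this carbon. They also leave open what a much smaller group, such as an amine or a carboxylic acid, would do there.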